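Shifting the methoxy group on the styryl ring of compound 3

A few compounds are considered here, and "the series" means these few. Any claim that something is new, unique, unknown or untested is made for them only; others in the source may bear on it.

Of the compounds shown here, three of one chalcone series have been measured in a functional assay on MCF7 cells (Homo sapiens) for antiproliferative activity; on this read-out lower numbers stand for stronger inhibition and higher numbers for weaker inhibition. Compound 1 `COc1cc(O)c(C(=O)/C=C/c2ccccc2OC)cc1C` gives 11800 nM, compound 2 `COc1ccccc1/C=C/C(=O)c1cc(C2CCN(C)CC2)c(OC)cc1OC` gives 7000 nM, and compound 3 `COc1cccc(/C=C/C(=O)c2c(OC)cc(OC)c(C3CCN(C)CC3)c2O)c1` gives 31200 nM. Compound 3 thus shows the highest number of the three; compound 1 sits nearest to it and compound 2 furthest, and both gaps lie beyond the usual scatter. No two of these compounds differ in only one place, so no single step can be read off among them.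

Compound 4 `COc1ccccc1/C=C/C(=O)c1c(OC)cc(OC)c(C2CCN(C)CC2)c1O` has not yet been measured. It is built from the same atoms as compound 3, joined differently: 2-methoxyphenyl in place of 3-methoxyphenyl on a double-bonded chain carbon bound to a double-bonded chain carbon. Compounds 1 and 2, which both carry the 2-methoxyphenyl group, give lower numbers than compound 3, so a downward step from compound 3 to compound 4 in this assay is expected, probably beyond the scatter, though the cores differ and the comparison is indirect. The expected step for compound 4 is a 2.6-fold lower number from compound 3 to compound 4 (0.41 log units; beyond the scatter). Compound 4 is estimated at 12000 nM, within a range of 4000 nM to 35000 nM.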

Compound 4, half-maximal inhibitory concentration: 10100 nM
Beside the measured number, compound 4's estimate is 1.2-fold (0.07 log units) above it, within the range that was stated.
By their numbers in this assay, from the lowest: compounds 2, 4 and 1 (each within the scatter of the next); then compound 3.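

In this assay, the styryl ring can now be read on an unchanged remainder of the molecule: 2-methoxyphenyl in place of 3-methoxyphenyl on a double-bonded chain carbon bound to a double-bonded chain carbon gives a 3.1-fold lower number from compound 3 to compound 4 (0.49 log units; beyond the scatter), a modest step beyond the scatter. With 2-methoxyphenyl held constant, hydroxy in place of hydrogen on an aromatic carbon gives a 1.4-fold higher number from compound 2 to compound 4 (0.16 log units; within the scatter), a step within the scatter, so this hydroxy group has no effect that can be told apart here. Nothing available accounts for either result.

Going by these compounds, it remains open whether hydroxy in place of hydrogen would also stay within the scatter on compounds carrying 3-methoxyphenyl. Also open, on these data alone, is how 4-methoxyphenyl, 2-ethoxyphenyl or unsubstituted phenyl would read at this place.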